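Three Esters at the Assay Limit, and a Biphenyl Newcomer

The compounds below may be only part of what the source reports. "The series", "measured", "known", "first", "only" and "open" are said of these compounds alone.

Compound 1 `COc1ccc(OC(=O)c2cn(-c3ccccc3)nc2-c2ccncc2)cc1` gives > 100000 nM in a functional assay on MDA-MB-231 cells (Homo sapiens) for cytotoxicity, read by MTT assay, with a stated time of 48 h (on this read-out higher numbers stand for weaker inhibition and lower numbers for stronger inhibition), which is a limit of the assay and not a number.
Compound 2 `CC(C)c1cccc(OC(=O)c2cn(-c3ccccc3)nc2-c2ccncc2)c1` gives > 100000 nM in this assay, again a limit.
Compound 3 `Cc1ccc(C(C)C)c(OC(=O)c2cn(-c3ccccc3)nc2-c2ccncc2)c1` gives > 100000 nM in this assay, again a limit.

All three share the same core and differ only in the aryl group on the oxygen next to the carbonyl group. Compound 1 therefore stands at a limit, and nothing shown ranks it against compound 2 or compound 3. The steps between them, a step that the two limits leave unreadable from compound 1 to compound 2, a step that the two limits leave unreadable from compound 1 to compound 3 and a step that the two limits leave unreadable from compound 2 to compound 3, carry no readable size because of the limit of > 100000 nM in this assay, at which 3 of the 3 values shown sit.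

Compound 4 `O=C(Oc1ccc(-c2ccccc2)cc1)c1cn(-c2ccccc2)nc1-c1ccncc1` differs from compound 1 as follows: phenyl in place of methoxy on an aromatic carbon. The three measured steps all bear on an exchange of the aryl group at this position, yet none of them has a readable size, so they give no direction for the change in this assay. What they do show is that three different aryl groups each left the reading at a limit.

Compound 4 is therefore expected to give 150000 nM, with a range from 40000 nM to 500000 nM. The step this estimate means is a step that the limit leaves unreadable from compound 1 to compound 4, and a further limit is the most likely outcome.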

Compound 4, half-maximal inhibitory concentration: > 100000 nM
Compound 4 ended at the assay's limit (the forecaster's own chance of this, stated with the estimate: 80%); the middle value does not contradict the limit.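

Compound 4 and compound 1 both stand at a limit, so no size can be read for the step between them, the exchange of methoxy for phenyl: the limit of > 100000 nM in this assay, at which 4 of the 4 values shown sit.

The compounds shown leave open how these aryl groups rank against one another, and whether any change to the shared core would give a true number in this assay.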